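The source may report more compounds than this note shows. Statements on the series, on what has been measured and on what is new or still open speak of the compounds shown alone.

Of the compounds shown here, three have been measured so far in a functional assay on NCI-H1650 cells (Homo sapiens) for cytotoxicity, read by MTT assay, with a stated time of 72 h; a lower number here means a stronger inhibitor, a higher number a weaker inhibitor. Compound 1 `COc1ccc(/C=C2\CNC/C(=C\c3ccc(OC)c(OC)c3)C2=O)cc1OC` gives 16700 nM, and compound 3 `COc1ccc(/C=C2\CN(C)C/C(=C\c3ccc(OC)c(OC)c3)C2=O)cc1OC` gives 9000 nM. Compound 2 `COc1cc(/C=C2\CN(C)C/C(=C\c3cc(OC)c(OC)c(OC)c3)C2=O)cc(OC)c1OC` gives 1500 nM, the lowest of the three numbers, which makes it the strongest inhibitor of the set so far.

Compound 4 `COc1cc(/C=C2\CN(C(=O)c3ccccc3F)C/C(=C\c3cc(OC)c(OC)c(OC)c3)C2=O)cc(OC)c1OC` has not yet been measured. It differs from compound 2 in one place, with (2-fluorophenyl)carbonyl in place of methyl on an amine nitrogen in a ring.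

Among the measured compounds shown here, only one measured step involves that nitrogen. Putting methyl in place of hydrogen there gave a 1.9-fold lower number from compound 1 to compound 3 (0.27 log units; within the scatter), a change within the scatter. This is thin guidance, as that step is small, while the incoming group is much larger and adds an aromatic ring and a carbonyl. For the measured compounds named here, no measured compound carries such a group, so the data offer no firm direction. Going by the values given here, with only that one small step to go on, no change beyond the scatter is expected in this assay, and the estimated change is a 1.7-fold lower number from compound 2 to compound 4 (0.22 log units; within the scatter). For compound 4 the estimate is 900 nM, with an expected range from 200 nM to 4000 nM, kept wide to reflect this uncertainty.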

Compound 4, half-maximal inhibitory concentration: 1900 nM
Compound 4: middle estimate off by 2.1-fold (0.32 log units), on the low side, within the range that was stated.
By their numbers in this assay, from the lowest: compounds 2 and 4 (each within the scatter of the next); then compounds 3 and 1 (each within the scatter of the next).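

In this assay, the amine nitrogen in the ring accepts a far larger group than the earlier compounds had shown: with (2-fluorophenyl)carbonyl in place of methyl, the result is a 1.3-fold higher number from compound 2 to compound 4 (0.10 log units; within the scatter). Among the compounds shown here, until now the only step at this nitrogen was the small swap of hydrogen for methyl, a 1.9-fold lower number from compound 1 to compound 3 (0.27 log units; within the scatter), which said little about a group that brings a six-membered aromatic ring and a carbonyl. Nothing available explains why so large a change in structure leaves the number within the scatter.

Compound 4 is the only compound shown with a carbonyl on this nitrogen, so the separate parts played by the carbonyl, the aromatic ring and the fluorine remain unresolved, and a plain benzoyl group, an acetyl group or a benzyl group could help to pull them apart. Going by these compounds, it also remains open whether a group ending in a carboxylic acid or an amine on a longer chain at this nitrogen would move the number beyond the scatter.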